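A Chlorophenyl Replaces a Methylphenyl on the Shared Core

The source may hold more compounds than are shown below. What is called first, only, known or untested is meant among the compounds shown, and "the series" means these compounds.

The shared core carries a 2,4-difluorophenyl group and a piperazine-bearing side chain, and the compounds differ in the aryl group on the five-membered ring. Compound 1 `CN1CCN(CCCNCc2cn(-c3ccc(C(F)(F)F)cc3)nc2-c2ccc(C(F)(F)F)cc2)CC1` gives 2000 nM in an ADME assay on Huh-7 cells (Homo sapiens) for cytotoxicity; on this read-out higher numbers stand for lower toxicity in this test and lower numbers for higher toxicity in this test. For compound 2 `Cc1cccc(-c2nn(-c3ccc(F)cc3F)cc2CNCCN2CCN(C)CC2)c1` this assay reports only a limit, > 20000 nM. For compound 3 `Cc1ccccc1-c1nn(-c2ccc(F)c(F)c2)cc1CNCCN1CCN(C)CC1` this assay likewise reports only a limit, > 20000 nM. Compound 2 thus stands at the limit of > 20000 nM in this assay, at which 2 of the 3 values shown sit. Compound 4 `CN1CCN(CCNCc2cn(-c3ccc(F)cc3F)nc2-c2ccc(Cl)cc2)CC1` differs from compound 2 in one place: 4-chlorophenyl in place of 3-methylphenyl on an aromatic carbon. Among the measured compounds shown here, no measured step between compounds exists here; the expected step is an at least 1.4-fold lower number from compound 2 to compound 4 (0.15 log units; that floor lies within the scatter), a small shift toward the value of compound 1, within or barely beyond the scatter. Compound 4 is therefore estimated at 14000 nM, between 5000 nM and 40000 nM.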

Compound 4, half-maximal cytotoxic concentration: 19000 nM
Beside the measured number, compound 4's estimate is 1.4-fold (0.13 log units) below it; the measured number falls inside the stated range.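

In this assay, 4-chlorophenyl in place of 3-methylphenyl on this aromatic carbon gives an at least 1.0-fold lower number from compound 2 to compound 4 (0.02 log units; that floor lies within the scatter). Among the compounds shown here, this is the first step readable at this position, and its floor shows no clear shift, although its true size remains unknown. Compound 2 gives only a limit and not a number: the limit of > 20000 nM in this assay, at which 2 of the 4 values shown sit.

On these data alone, it remains open how a pyridyl group or a 4-methoxyphenyl group would read on this carbon. As far as these compounds go, it also remains open whether 4-chlorophenyl would give the same result with a different side chain on the shared core.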